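The source may report more compounds than this note shows. Statements on the series, on what has been measured and on what is new or still open speak of the compounds shown alone.

Measured in a functional assay on SH-SY5Y cells (Homo sapiens) for cytotoxicity, read by MTT assay, with a stated time of 72 h; on this read-out lower numbers stand for stronger inhibition and higher numbers for weaker inhibition:
- Compound 1 `CC1(C)OCC(Cn2cc(Cn3c4c(c5ccccc53)C(=O)c3c[n+]([O-])c5ccccc5c3C4=O)nn2)O1`: 230 nM
- Compound 2 `O=C1c2c[n+]([O-])c3ccccc3c2C(=O)c2c1c1ccccc1n2Cc1cn(CC(O)CO)nn1`: > 1000 nM, a limit of the assay
- Compound 3 `CC1(C)O[C@@H](CO)[C@H](Cn2cc(Cn3c4c(c5ccccc53)C(=O)c3c[n+]([O-])c5ccccc5c3C4=O)nn2)O1`: > 1000 nM, a limit of the assay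

Compound 3 has no number in this assay and sits at the limit of > 1000 nM in this assay, at which 2 of the 3 values shown sit. Compound 4 `CC1(C)OC[C@H](Cn2cc(Cn3c4c(c5ccccc53)C(=O)c3c[n+]([O-])c5ccccc5c3C4=O)nn2)O1` differs from it by hydrogen in place of hydroxymethyl on a saturated ring carbon.

The measured step closest to this change is an at least 4.3-fold higher number from compound 1 to compound 3 (0.63 log units; beyond the scatter). It exchanges the same two groups in the opposite sense and lies beyond the scatter. A second step, with 1,2-dihydroxyethyl in place of 2,2-dimethyl-1,3-dioxolan-4-yl, is an at least 4.3-fold higher number from compound 1 to compound 2 (0.63 log units; beyond the scatter), and it also runs toward the limit. The step that the two limits leave unreadable from compound 2 to compound 3 cannot be read. Losing the hydroxymethyl should therefore reverse the direction of the closest step and bring the number back toward that of compound 1, at 230 nM.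

The expected step, an estimate only, is an at least 4.0-fold lower number from compound 3 to compound 4 (0.60 log units; beyond the scatter), toward a lower number. Compound 4 is expected at 250 nM, with an estimated range of 110 nM to 600 nM.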

Compound 4, half-maximal inhibitory concentration: 820 nM
Estimate against measurement, compound 4: 3.3-fold (0.52 log units) below, and the stated range ends below it.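

In this assay, hydrogen in place of hydroxymethyl on the saturated ring carbon gives an at least 1.2-fold lower number from compound 3 to compound 4 (0.08 log units; that floor lies within the scatter), and 2,2-dimethyl-1,3-dioxolan-4-yl in place of 1,2-dihydroxyethyl gives an at least 1.2-fold lower number from compound 2 to compound 4 (0.08 log units; that floor lies within the scatter); both floors lie within the scatter. Compound 2 and compound 3 carry only a limit, so these floors do not show that either change moves the number: the limit of > 1000 nM in this assay, at which 2 of the 4 values shown sit. Within the data shown here, the one readable step is a 3.6-fold higher number from compound 1 to compound 4 (0.55 log units; beyond the scatter), which lies beyond the scatter, and the sole difference in that pair is in how the stereocentre is drawn: the fact that one of compounds 1 and 4 is drawn with a defined configuration and the other without, at the place where they differ.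

The compounds shown leave open how far the number would move with the opposite configuration drawn at that stereocentre. They also leave open how an aminomethyl group or a carboxylic acid on the same ring carbon would read.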